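Working notes on the shared core: compound 1 toward compound 4

This account rests on a few compounds, and the source may have more. Where it says the series, first, only, none or still open, it means among the compounds named here.

compound 1 `Nc1cc(N)c2nc(-c3ccccc3)c(Oc3ccc(Cl)c(Cl)c3)nc2c1` — < 100000 nM, a limit of the assay
compound 2 `Nc1cc(N)c2nc(-c3ccccc3)c(NCc3ccc(Cl)c(Cl)c3)nc2c1` — < 100000 nM, a limit of the assay
compound 3 `CCOC(=O)[C@H](CCC(=O)O)NC(=O)c1ccc(Sc2nc3cc(N)cc(N)c3nc2-c2ccccc2)cc1` — 53700 nM

In a functional assay on OVCAR-4 cells (Homo sapiens) for inhibition, read by sulforhodamine B assay, with a stated time of 48 h (on this read-out lower numbers stand for stronger inhibition of growth and higher numbers for weaker inhibition of growth), compound 1 gives no number, only the limit < 100000 nM. Compound 2 in this assay also gives only the limit < 100000 nM. Within the data shown here, compound 3 is the one member of the set with a measured number, 53700 nM in this assay, and it lies near the weak end of the scale. Compound 1 therefore stands at the limit of < 100000 nM in this assay, at which 2 of the 3 values shown sit, and its place among the three cannot be fixed more closely.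

Compound 4 `Nc1cc(N)c2nc(-c3ccccc3)c(Sc3ccc(F)cc3)nc2c1` differs from compound 1 by (4-fluorophenyl)sulfanyl in place of 3,4-dichlorophenoxy on an aromatic carbon. Among the measured compounds shown here, no step between two measured compounds with a single change is available, so the size of the change in this assay has to be guessed from the spread of the three values alone. Compound 4 is expected to land in the same weak region, with an expected step that the limit leaves unreadable from compound 1 to compound 4 that is small and could well sit within the scatter. The estimate for compound 4 in this assay is 40000 nM, with a range from 8000 nM to 100000 nM.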

Compound 4, concentration for total growth inhibition: 56200 nM
Estimate against measurement, compound 4: 1.4-fold (0.15 log units) below, within the range that was stated.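

In this assay no step can be read from compound 1 to compound 4, because compound 1 stands at a limit of the assay and not at a number: the limit of < 100000 nM in this assay, at which 2 of the 4 values shown sit.

The compounds shown leave open how far (4-fluorophenyl)sulfanyl and 3,4-dichlorophenoxy differ on the shared core.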